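The source may hold more compounds than are shown below. What is called first, only, known or untested is meant among the compounds shown, and "the series" means these compounds.

Measured compounds:
- compound 1 `CCOC(=O)C1=C(Nc2ccccc2)S/C(=C\c2ccc(OC)cc2)C1=O`: 9.6%
- compound 2 `CCOC(=O)C1=C(Nc2ccccc2)S/C(=C\c2ccc(C(=O)O)cc2)C1=O`: 27.5%
- compound 3 `CCOC(=O)C1=C(Nc2ccccc2)S/C(=C\c2ccc[nH]2)C1=O`: 16.2%

In a functional assay on K562 cells (Homo sapiens) for inhibition, read by MTT assay, with a stated time of 72 h, tested at 10 uM (on this read-out higher numbers stand for more inhibition at the one concentration tested (going by the name of the read-out) and lower numbers for less inhibition), compound 3 stands second highest of the three numbers. Its nearest neighbour is compound 1, and the step of a number 6.6 percentage points higher from compound 1 to compound 3 (within the scatter) lies within the scatter; its furthest is compound 2, and the step of a number 11.3 percentage points lower from compound 2 to compound 3 (beyond the scatter) lies beyond it. The other measured step, a number 17.9 percentage points higher from compound 1 to compound 2 (beyond the scatter), is the largest of the set.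

Compound 4 `CCOC(=O)C1=C(Nc2ccccc2Br)S/C(=C\c2ccc[nH]2)C1=O` differs from compound 3 by bromo in place of hydrogen on an aromatic carbon. All three measured steps concern the group on the double-bonded chain carbon, so none of them bears on a change to the anilino ring, and the data give no guide to the effect of the bromo group there. With nothing to point either way, no step beyond the scatter is expected in this assay, and the step of a number 0.8 percentage points higher from compound 3 to compound 4 (within the scatter) is estimated accordingly. Compound 4 is therefore expected to give about 17% in this assay, with a range from 4% to 36%.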

Compound 4, a percentage reported as inhibition, at one concentration (the size of the read-out at that concentration, not a potency): 20.5%
Compound 4: middle estimate off by 3.5 percentage points, on the low side; measured number inside the range.
By their numbers in this assay, from the lowest: compounds 1, 3, 4 and 2 (each within the scatter of the next, the first and the last beyond it).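

Going by these compounds alone, replacing phenyl with 2-bromophenyl is the only change in this set made on the anilino ring rather than at the group on the double-bonded chain carbon, and in this assay it gives a number 4.3 percentage points higher from compound 3 to compound 4 (within the scatter). A bromo group on this aromatic carbon, ortho to a large group, therefore produces no change beyond the scatter when 1H-pyrrol-2-yl is the group on the chain carbon, so this read-out does not separate the two compounds. No supporting measurement bears on this result or gives any property of the bromo group.

As far as these compounds go, whether the same change would behave alike with the 4-methoxyphenyl of compound 1 or the 4-carboxyphenyl of compound 2 remains open. Also open, from the compounds shown here alone, is what a chlorine atom, a methoxy group or an amine would do on the same aromatic carbon.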